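Replacing the bromo group of compound 1 with methylamino

The compounds below may be only part of what the source reports. "The series", "measured", "known", "first", "only" and "open" are said of these compounds alone.

Measured compounds:
compound 1, `COc1ccc(C(=O)c2ccc(OC)c3c2OC(C)(C)C=C3)c(NC(=O)CBr)c1`, 3250 nM
compound 2, `COc1ccc(C(=O)c2ccc(OC)c3c2C=CC(C)(C)O3)c(NC(=O)CN)c1`, 1050 nM

Of the compounds shown here, two have so far been tested in a functional assay on HCT-8 cells (Homo sapiens) for antiproliferative activity, read by MTT assay, with a stated time of 48 h; on this read-out higher numbers stand for weaker inhibition and lower numbers for stronger inhibition. Compound 1, `COc1ccc(C(=O)c2ccc(OC)c3c2OC(C)(C)C=C3)c(NC(=O)CBr)c1`, gives 3250 nM, the highest number of the two. Compound 2, `COc1ccc(C(=O)c2ccc(OC)c3c2C=CC(C)(C)O3)c(NC(=O)CN)c1`, gives 1050 nM, a lower number that lies beyond the usual scatter, so compound 2 inhibits more strongly than compound 1.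

The next compound, compound 3, `CNCC(=O)Nc1cc(OC)ccc1C(=O)c1ccc(OC)c2c1OC(C)(C)C=C2`, shares the core of compound 1 and differs from it at one point: methylamino in place of bromo on a saturated chain carbon bound to a carbonyl carbon. Within the data shown here, compound 2 carries a primary amine at the corresponding place, and compound 3 a secondary one; no step between the two measured compounds is on hand to anchor this.

Because compound 2 gives 1050 nM against the higher number of compound 1, a similar change in compound 3 is expected to lower the number. The step of a 2.7-fold lower number from compound 1 to compound 3 (0.43 log units; beyond the scatter) is estimated to be beyond the scatter. Compound 3 is expected to give 1200 nM in this assay, within a range of 400 nM to 3500 nM.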

Compound 3, half-maximal inhibitory concentration: 740 nM
The estimate for compound 3 lay 1.6-fold (0.21 log units) above the measured number; low and high end bracket the measured number.
By their numbers in this assay, from the lowest: compounds 3 and 2 (each within the scatter of the next); then compound 1.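

In this assay, among these compounds, methylamino in place of bromo on a saturated chain carbon bound to a carbonyl carbon gives a 4.4-fold lower number from compound 1 to compound 3 (0.64 log units; beyond the scatter), and this is the first step that changes one place on one shared core, something the two earlier compounds could not offer. As the step lies beyond the scatter, it shows that this position responds to what it carries: the number falls when a single bromine gives way to a carbon and a nitrogen, which bring in a hydrogen-bond donor and a hydrogen-bond acceptor. No measurement on hand bears on why the number falls with this exchange.

This single step cannot show whether the lower number follows from the loss of bromo or from the entry of the secondary amine, and a chloro group at the same place would help to separate the two. It also leaves open how far this position tolerates further change, which a dimethylamino group, a piperidine or a longer chain ending in an amine on the same core could test.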